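Bis-benzylidene cyclanones: cytotoxicity notes, methoxy for chloro

The source may hold more compounds than are shown below. What is called first, only, known or untested is meant among the compounds shown, and "the series" means these compounds.

Measured compounds in a functional assay on HSG cells (Homo sapiens) for cytotoxicity; a higher number here means that more compound is tolerated, a lower number that less compound is tolerated:
compound 1 `COc1cc(/C=C2\CCC/C(=C\c3ccc([N+](=O)[O-])cc3)C2=O)ccc1O` — 11000 nM
compound 2 `O=C1/C(=C/c2ccc(Cl)cc2)CCC/C1=C\c1ccc([N+](=O)[O-])cc1` — 15000 nM
compound 3 `COc1ccc(/C=C2\CC/C(=C\c3ccc([N+](=O)[O-])cc3)C2=O)cc1` — > 400000 nM, which is a limit of the assay and not a number

Compound 2 holds the higher of the two numbers; the nearest is compound 1, and the step of a 1.4-fold higher number from compound 1 to compound 2 (0.13 log units; within the scatter) lies within the scatter, so no order between compound 1 and compound 2 is claimed. Compound 3 sits at a limit of this assay the limit of > 400000 nM in this assay, at which 1 of the 3 values shown sits, and contributes no number.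

Compound 4 `COc1ccc(/C=C2\CCC/C(=C\c3ccc([N+](=O)[O-])cc3)C2=O)cc1` differs from compound 2 in one place: methoxy in place of chloro on an aromatic carbon. Among the compounds with values here, the only measured step, the swap of the aryl group on the same chain carbon between compound 1 and compound 2, stayed within the scatter. Compound 3, which carries the 4-methoxyphenyl group on a different core, reaches only a limit. On this basis a modest rise in the tolerated concentration is expected for compound 4, with a real chance that this assay again reports only a limit; the expected step is a 2.0-fold higher number from compound 2 to compound 4 (0.30 log units; within the scatter). The estimate for compound 4 is 30000 nM, with a range from 10000 nM to 300000 nM.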

Compound 4, half-maximal cytotoxic concentration: > 400000 nM
Compound 4: a limit, no number; the forecaster's own chance of this, stated with the estimate: 25%; middle value at least 13-fold (1.12 log units) away from the limit.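

In this assay, the aryl group on this chain carbon now proves able to shift the read-out: an at least 26-fold higher number from compound 2 to compound 4 (1.42 log units; beyond the scatter), and an at least 36-fold higher number from compound 1 to compound 4 (1.56 log units; beyond the scatter). Both steps lie beyond the scatter, whereas the earlier swap at the same place stayed within it, a 1.4-fold higher number from compound 1 to compound 2 (0.13 log units; within the scatter), so a large change here depends on which aryl group enters, and 4-methoxyphenyl is the one that produces it among the three shown. Compound 4 gives a limit and not a number, so both new steps have a floor but no measured size: the limit of > 400000 nM in this assay, at which 2 of the 4 values shown sit.

As far as these compounds go, how far compound 4 lies past that limit stays open, and so does any effect of the core in compound 3, which also gives only a limit. Also open, from the compounds shown here alone, is how an amine or a carboxylic acid on this aromatic carbon would read in this assay, and whether methoxy alone, without the rest of the 4-methoxyphenyl pattern changing, would give the same step on another core.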